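Cyclohexyl for tert-butyl on the amide aryl ring

This account rests on a few compounds, and the source may have more. Where it says the series, first, only, none or still open, it means among the compounds named here.

Measured compounds, each with its value in an assay on HEK293 cells for displacement of a labelled ligand from NPC1-like intracellular cholesterol transporter 1 (Homo sapiens); a lower number here means a stronger inhibitor, a higher number a weaker inhibitor:
compound 1, `CC(C)(C)c1ccc(C(=O)N2CCC3(CC2)C(=O)N(CC(=O)N2CCN(S(C)(=O)=O)CC2)CN3c2ccccc2)cc1`, gives 19000 nM;
compound 2, `CC(C)(C)c1ccc(C(=O)N2CCC3(CC2)C(=O)N(CC(=O)NCCN)CN3c2ccccc2)cc1`, gives 7000 nM;
compound 3, `CC1(C)CC(OC(=O)CN2CN(c3ccccc3)C3(CCN(C(=O)c4ccc(C(C)(C)C)cc4)CC3)C2=O)CC(C)(C)N1`, gives 1300 nM.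

Compound 1 has the highest number of the three, with compound 2 nearest, a 2.7-fold lower number from compound 1 to compound 2 (0.43 log units; beyond the scatter), and compound 3 furthest, a 15-fold lower number from compound 1 to compound 3 (1.16 log units; beyond the scatter). Compound 4, `CS(=O)(=O)N1CCN(C(=O)CN2CN(c3ccccc3)C3(CCN(C(=O)c4ccc(C5CCCCC5)cc4)CC3)C2=O)CC1`, differs from compound 1 only at the other end of the shared core: cyclohexyl in place of tert-butyl on an aromatic carbon. Within the data shown here, none of the measured steps touches this position; all three vary the group on the carbonyl carbon, so none bears on the change in hand. With no guidance from the data, the expected step in this assay is small or none beyond the scatter, a 1.3-fold lower number from compound 1 to compound 4 (0.10 log units; within the scatter). Compound 4 is therefore estimated at 15000 nM, with a range from 5000 nM to 45000 nM.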

Compound 4, half-maximal inhibitory concentration: 6300 nM
Compound 4: the middle estimate sits 2.4-fold (0.38 log units) above what was measured; measured number inside the range.
By their numbers in this assay, from the lowest: compound 3; then compounds 4 and 2 (each within the scatter of the next); then compound 1.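

Among these compounds, the step from tert-butyl to cyclohexyl in this assay is the first measured change at this end of the molecule, and it gives a 3.0-fold lower number from compound 1 to compound 4 (0.48 log units; beyond the scatter) with the 4-(methylsulfonyl)piperazin-1-yl group held fixed. This position therefore affects the number, and a six-membered carbon ring is tolerated here in place of tert-butyl.

Still open, going by these compounds, is whether the same change would lower the number with the (2,2,6,6-tetramethylpiperidin-4-yl)oxy group of compound 3 in place, and how a phenyl ring or a methoxy group would fare on this aromatic carbon. No measurement shown here explains the step.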